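Fluorine Position on the Ring-Bound Phenyl Group

The source may hold more compounds than are shown below. What is called first, only, known or untested is meant among the compounds shown, and "the series" means these compounds.

In a functional assay on the whole organism (strain CD1) with Mus musculus as the target, in the maximal electroshock model, with a stated time of 4 h (a higher number here means that more compound is needed for the effect, a lower number that less compound is needed), compound 1 `O=C1NC(c2ccccc2)(c2ccccc2)C(=O)N1CN1CCN(c2ccccc2)CC1` gives 100 mg/kg, compound 2 `CC(C)C1(C(C)C)NC(=O)N(CN2CCN(c3ccc(F)cc3)CC2)C1=O` gives 100 mg/kg, and compound 3 `O=C1NC(c2ccccc2)(c2ccccc2)C(=O)N1CN1CCN(c2cccc(C(F)(F)F)c2)CC1` gives 100 mg/kg. Compound 2 thus stands level with compounds 1 and 3, all three within the scatter of one another. Among the measured compounds shown here, the only measured step, no change at the digits printed from compound 1 to compound 3 (within the scatter), puts trifluoromethyl in place of hydrogen on an aromatic carbon without moving the dose beyond the scatter. Compound 4 `CC(C)C1(C(C)C)NC(=O)N(CN2CCN(c3ccccc3F)CC2)C1=O` differs from compound 2 by 2-fluorophenyl in place of 4-fluorophenyl on an amine nitrogen in a ring. For the measured compounds named here, no measured step covers a shift of fluorine position, but the one change made on the aromatic ring stayed within the scatter, so no step beyond the scatter is expected in this assay. Compound 4 is therefore estimated at 100 mg/kg, between 50 mg/kg and 200 mg/kg, with an expected step of no change at the digits printed from compound 2 to compound 4 (within the scatter).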

Compound 4, minimum effective dose: 100 mg/kg
Compound 4: the middle estimate sits on the measured number at the digits printed; low and high end bracket the measured number.
By their numbers in this assay, from the lowest: compounds 1, 2, 3 and 4 (each within the scatter of the next).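

In this assay, among the compounds shown here, the change of 2-fluorophenyl for 4-fluorophenyl on the amine nitrogen in a ring gives no change at the digits printed from compound 2 to compound 4 (within the scatter) and so adds what the earlier compounds did not show: a step in which only the fluorine position changes. On the core of compound 2, this position tolerates that change without a shift beyond the scatter. Nothing shown accounts for this result. The compounds shown leave open whether a carboxylic acid or an amine on this phenyl group would move the dose, and whether any change here would give a step beyond the scatter.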